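Methyl for phenyl on the shared core of compound 2

The source may hold more compounds than are shown below. What is called first, only, known or untested is meant among the compounds shown, and "the series" means these compounds.

Measured so far:
compound 1 `Cc1cc2nc(N)nc(N)c2c(=O)[nH]1`: 8%
compound 2 `Cc1cc2nc(-c3ccccc3)nc(N)c2c(=O)[nH]1`: -17%

In an assay on isolated protein for inhibition of protein kinase C zeta type (Homo sapiens), read by mobility shift assay, tested at 30 uM (a lower number here means less inhibition, a higher number more inhibition at the concentration tested (going by the name of the read-out)), compound 2 gives -17%, the lowest of the two numbers; its nearest neighbour, compound 1, sits higher by a number 25 percentage points lower from compound 1 to compound 2 (beyond the scatter). Compound 3 `Cc1nc(N)c2c(=O)[nH]c(C)cc2n1` is not yet measured. It differs from compound 2 by methyl in place of phenyl on an aromatic carbon. Among the measured compounds shown here, the one measured step concerns the same place and was modest, but it exchanged amino for phenyl, not phenyl for methyl, so it bears only loosely. A small upward step is expected, about a number 17 percentage points higher from compound 2 to compound 3 (beyond the scatter). Compound 3 is therefore estimated at 0%, with a range from -20% to 18%.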

Compound 3, a percentage reported as inhibition, at one concentration (the size of the read-out at that concentration, not a potency): 3%
Compound 3: middle estimate off by 3 percentage points, on the low side; low and high end bracket the measured number.
By their numbers in this assay, from the lowest: compound 2; then compounds 3 and 1 (each within the scatter of the next).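

In this assay, methyl in place of phenyl on the aromatic carbon between two ring nitrogen atoms gives a number 20 percentage points higher from compound 2 to compound 3 (beyond the scatter), so the lower number does not extend to every carbon group at this position. Methyl in place of amino gives a number 5 percentage points lower from compound 1 to compound 3 (within the scatter), leaving these two groups indistinguishable here and phenyl alone apart from both. No independent evidence bears on this difference.

The compounds shown leave open whether an ethyl chain, a methoxy group or a carboxylic acid here would fall with methyl and amino or with phenyl.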